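The compounds below may be only part of what the source reports. "The series", "measured", "known", "first", "only" and "open" are said of these compounds alone.

Measured so far in a toxicity assay on THP-1 cells (Homo sapiens) for inhibition; a higher number here means that more compound is tolerated, a lower number that less compound is tolerated:
- compound 1 `Cc1ccccc1-c1cnc(NC(=O)c2ccc(F)cc2)n1C`: > 50000 nM, a limit
- compound 2 `Cn1c(-c2ccc(C#N)cc2)cnc1NC(=O)c1ccc(F)cc1`: > 50000 nM, a limit

Compound 2 has no number of its own, only the limit > 50000 nM. The series as a whole stands at the limit of > 50000 nM in this assay, at which 2 of the 2 values shown sit.

Compound 3 `Cn1c(-c2cccc(C#N)c2)cnc1NC(=O)c1ccc(F)cc1` is the next to be read. It carries 3-cyanophenyl in place of 4-cyanophenyl on an aromatic carbon, and the two compounds have the same atoms, joined differently: 3-cyanophenyl in place of 4-cyanophenyl on an aromatic carbon.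

Going by the values given here, only one measured step bears on this change, and it also concerns the group at that aromatic carbon: a step that the two limits leave unreadable from compound 1 to compound 2. That step gives no size to carry over, so the expectation rests on the shared limit alone. No step beyond the scatter is expected in this assay, and no direction can be assigned. The expected change is a number no higher from compound 2 to compound 3 (the limit leaves the size open), an estimate that rests on no readable step. For compound 3 the estimated value is 50000 nM, with an expected range from 25000 nM to 100000 nM, and a report as a limit is the likeliest outcome.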

Compound 3, half-maximal cytotoxic concentration: > 100000 nM
Compound 3 gave a limit, no number (the forecaster's own chance of this, stated with the estimate: 85%); middle value at least 2.0-fold (0.30 log units) from the limit.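

In this assay compound 3 gives > 100000 nM, a limit and not a number. The steps from compound 1 and from compound 2 to compound 3 cannot be read, as all three values are limits. The compounds shown leave open whether 2-methylphenyl, 4-cyanophenyl and 3-cyanophenyl differ at all in tolerated concentration.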